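Replacing hydroxy with azido on compound 1

The source may report more compounds than this note shows. Statements on the series, on what has been measured and on what is new or still open speak of the compounds shown alone.

compound 1 `Nc1ccnc2c1ncn2[C@@H]1O[C@H](CO)[C@](O)(CO)[C@H]1O`: 37300 nM
compound 2 `CNc1ccnc2c1ncn2[C@@H]1O[C@H](CO)[C@](O)(CO)[C@H]1O`: 11800 nM
compound 3 `Nc1ccn([C@@H]2O[C@H](CO)[C@](O)(CO)[C@H]2O)c(=O)n1`: 12300 nM

In an ADME assay on Huh-7 cells (Homo sapiens) for cytotoxicity, read by WST assay, with a stated time of 3 days (on this read-out higher numbers stand for lower toxicity in this test and lower numbers for higher toxicity in this test), compound 1 stands highest of the three at 37300 nM and its gaps to compound 2 and compound 3 lie beyond the scatter. Compound 4 `[N-]=[N+]=NC[C@@]1(O)[C@@H](CO)O[C@@H](n2cnc3c(N)ccnc32)[C@@H]1O` keeps the core of compound 1 and carries one change: azido in place of hydroxy on a saturated chain carbon bound to a saturated ring carbon. Among the measured compounds shown here, the only measured step is a 3.2-fold lower number from compound 1 to compound 2 (0.50 log units; beyond the scatter) for methyl in place of hydrogen on a nitrogen on an aromatic ring. For the measured compounds named here, that is a different change, so it is only a loose guide, and no measured compound carries azido. A small move toward lower numbers is therefore expected, possibly within the scatter, and the estimated step is a 1.7-fold lower number from compound 1 to compound 4 (0.23 log units; within the scatter) in this single comparison. In this assay compound 4 is expected at 22000 nM within an estimated range of 7000 nM to 70000 nM.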

Compound 4, half-maximal cytotoxic concentration: > 100000 nM
Compound 4: only a limit was reported; the forecaster's own chance of this, stated with the estimate: 15%; middle value at least 4.5-fold (0.65 log units) from the limit.
By their numbers in this assay, from the lowest: compounds 2 and 3 (each within the scatter of the next); then compound 1. At a limit, above all of these: compound 4.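

In this assay, azido in place of hydroxy on a saturated chain carbon bound to a saturated ring carbon gives an at least 2.6-fold higher number from compound 1 to compound 4 (0.42 log units; beyond the scatter), so this change moves toward lower toxicity in this test. Among the compounds shown here, the one earlier step, made on a nitrogen on an aromatic ring, went the other way. The reading for compound 4 is a limit, not a number: the limit of > 100000 nM in this assay, at which 1 of the 4 values shown sits.

From the compounds shown here alone, how far the step really reaches stays open. So does whether an amine in place of hydroxy at this same place would also raise the number, or whether the rise belongs to azido alone.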